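Fluoro for Trifluoromethyl: Expected Solubility of Compound 4

The source may report more compounds than this note shows. Statements on the series, on what has been measured and on what is new or still open speak of the compounds shown alone.

Compound 1, `Fc1ccc(Nc2cc3[nH]c(-c4cccc(C(F)(F)F)c4)nc3cn2)nc1`, gives in a physicochemical assay for solubility, using the shake flask method, measured as kinetic solubility, with a stated time of 20 h, at pH 2 (a lower number here means a less soluble compound, a higher number a more soluble compound), a result that is a limit, < 5000 nM.
Compound 2, `FC(F)(F)c1ccc(Nc2cc3[nH]c(-c4cccc(C(F)(F)F)c4)nc3cn2)nc1`, likewise gives only a limit in this assay, < 5000 nM.
Compound 3, `FC1(F)CCC(c2nc3cnc(Nc4ccc(C(F)(F)F)cn4)cc3[nH]2)CC1`, gives in this assay a number, 199000 nM.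

From compound 2 to compound 1 the change is fluoro in place of trifluoromethyl on an aromatic carbon, and its step in this assay is a step that the two limits leave unreadable from compound 2 to compound 1; it cannot be sized due to the limit of < 5000 nM in this assay, at which 2 of the 3 values shown sit. Compound 3 differs from compound 2 by 4,4-difluorocyclohexyl in place of 3-(trifluoromethyl)phenyl on an aromatic carbon, giving an at least 39-fold higher number from compound 2 to compound 3 (1.59 log units; beyond the scatter).

Compound 4, `Fc1ccc(Nc2cc3[nH]c(C4CCC(F)(F)CC4)nc3cn2)nc1`, is not yet measured. It differs from compound 3 by fluoro in place of trifluoromethyl on an aromatic carbon, the same change as from compound 2 to compound 1, at a place described in the same words. Since that earlier step gives no readable size, the step from compound 3 to compound 4 is expected to be small, a 1.3-fold higher number from compound 3 to compound 4 (0.10 log units; within the scatter). Compound 4 is thus estimated at 250000 nM, between 80000 nM and 600000 nM.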

Compound 4, solubility: 200000 nM
For compound 4 the middle estimate is 1.3-fold (0.10 log units) above the measured one; measured number inside the range.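

In this assay, fluoro in place of trifluoromethyl on the core carrying 4,4-difluorocyclohexyl gives a 1.0-fold higher number from compound 3 to compound 4 (0.00 log units; within the scatter). The same change from compound 2 to compound 1 cannot be read, so the two steps cannot be set side by side: the limit of < 5000 nM in this assay, at which 2 of the 4 values shown sit.

The result therefore shows a step within the scatter for this one pair, but it does not show that the change behaves the same way on the core carrying 3-(trifluoromethyl)phenyl. The compounds shown leave open whether the step stays within the scatter when an amine or a carboxylic acid stands in place of 4,4-difluorocyclohexyl. They also leave open what a nitrile would do at the place held by fluoro and trifluoromethyl.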